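This account rests on a few compounds, and the source may have more. Where it says the series, first, only, none or still open, it means among the compounds named here.

The shared core of this small series carries a carbonyl group, and the compounds differ only in the amine attached to that carbonyl carbon. Compound 1 `Cc1c(C(C)C)c(=O)on1C(=O)NC(C)(C)C` bears a (tert-butyl)amino group there. In an assay (strain Wistar) for inhibition of Hormone-sensitive lipase (Rattus norvegicus), read by spectrophotometry (on this read-out higher numbers stand for weaker inhibition and lower numbers for stronger inhibition), compound 1 gives only a limit of the assay, > 1000 nM. Compound 2 `Cc1c(C(C)C)c(=O)on1C(=O)N1CCNCC1` carries a piperazin-1-yl group instead. In this assay compound 2 likewise gives only a limit, > 1000 nM. The step that the two limits leave unreadable from compound 1 to compound 2 is thus of unreadable size, as the limit of > 1000 nM in this assay, at which 2 of the 2 values shown sit, shows. Compound 2 therefore stands at the limit, and no number places it more precisely. Compound 3 `Cc1c(C(C)C)c(=O)on1C(=O)N1CCN(c2ccccc2)CC1` comes from compound 2 by phenyl in place of hydrogen on an amine nitrogen in a ring. Among the compounds with values here, no measured step touches the amine nitrogen in the ring, and the single known step has no readable size, so the data set no expectation for the size or direction of this change. The estimate for compound 3 in this assay is nevertheless 800 nM, in a broad range from 100 nM to 5000 nM. Within the data shown here, this estimate means an expected step of an at least 1.2-fold lower number from compound 2 to compound 3 (0.09 log units; that floor lies within the scatter) that no measured step can confirm.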

Compound 3, half-maximal inhibitory concentration: 6 nM
Compound 3: the middle estimate sits 130-fold (2.12 log units) above what was measured; measured number below the stated range.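

Phenyl in place of hydrogen on the amine nitrogen in the ring brings an at least 160-fold lower number from compound 2 to compound 3 (2.22 log units; beyond the scatter) in this assay, and a lower number here means stronger inhibition. Within the data shown here, this nitrogen is therefore a place where a change can have a very large effect, something the earlier compounds could not show, and the true size of the step may be larger still, as compound 2 has only a limit and not a number. Compound 3 is also the first compound in this series with a readable value, so it gives any later change a measured point of comparison, while compound 1 and compound 2 remain unplaced: the limit of > 1000 nM in this assay, at which 2 of the 3 values shown sit.

The compounds shown leave open whether this effect belongs to phenyl in particular, or whether another group on the same nitrogen, such as methyl, benzyl or a pyridine ring, would lower the number as far. They also leave open whether a chlorine atom or a methoxy group added to the phenyl ring would move the number further in either direction.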